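Compound 4: chloro in place of bromo

The source may report more compounds than this note shows. Statements on the series, on what has been measured and on what is new or still open speak of the compounds shown alone.

In an ADME assay on Vero cells (Chlorocebus sabaeus) for cytotoxicity, read by MTT assay, with a stated time of 72 h (on this read-out lower numbers stand for an effect already at smaller amounts and higher numbers for an effect only at larger amounts of compound), compound 1 `Cc1ccccc1C(=O)Nc1nc(-c2ccccn2)cs1` gives 6300 nM and compound 2 `Cc1cccc(C(=O)Nc2nc(-c3ccccn3)cs2)c1` gives 4100 nM, two values within the scatter of each other. Compound 3 `O=C(Nc1nc(-c2ccccn2)cs1)c1cccc(Br)c1` has the highest number of the three, at 16100 nM.

Compound 4 `O=C(Nc1nc(-c2ccccn2)cs1)c1cccc(Cl)c1` carries chloro in place of bromo on an aromatic carbon, meta to a large group: chloro in place of bromo on an aromatic carbon.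

Among the compounds with values here, two measured steps bear on this change. With bromo in place of methyl on an aromatic carbon, the series shows a 3.9-fold higher number from compound 2 to compound 3 (0.59 log units; beyond the scatter). The change to 3-bromophenyl from 2-methylphenyl shows a 2.6-fold higher number from compound 1 to compound 3 (0.41 log units; beyond the scatter). Both are modest, while a 1.5-fold lower number from compound 1 to compound 2 (0.19 log units; within the scatter) shows that the two methyl compounds do not separate. Within the data shown here, no measured compound carries chloro, so the expectation is a partial return from compound 3 toward compound 2 at 4100 nM.

The expected change is small and downward, estimated as a 1.6-fold lower number from compound 3 to compound 4 (0.21 log units; within the scatter). Compound 4 is estimated at 10000 nM, with an expected range of 5000 nM to 20000 nM.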

Compound 4, half-maximal effective concentration: 7000 nM
The estimate for compound 4 lay 1.4-fold (0.15 log units) above the measured number; measured number inside the range.
By their numbers in this assay, from the lowest: compounds 2, 1 and 4 (each within the scatter of the next); then compound 3.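

In this assay the high number of compound 3 does not carry over to chloro on the same aromatic carbon, which gives a 2.3-fold lower number from compound 3 to compound 4 (0.36 log units; beyond the scatter) and so sets bromo apart from chloro among the halogens shown. Chloro and methyl at this place do not separate, with a 1.7-fold higher number from compound 2 to compound 4 (0.23 log units; within the scatter) and, for 3-chlorophenyl against 2-methylphenyl, a 1.1-fold higher number from compound 1 to compound 4 (0.05 log units; within the scatter), leaving compound 3 the only one of the four that stands apart. No measurement at hand accounts for this separation of bromo from chloro and methyl.

Going by these compounds, whether iodo continues the step seen with bromo, and whether an amine or a carboxylic acid on the same aromatic carbon moves the number in either direction, stays open. Also open, on these data alone, is how bromo or chloro would read in the place that methyl holds in compound 1.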